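From 5-hydroxypyridin-2-yl to 3-chloro-4-hydroxyphenyl on a shared core

The source may report more compounds than this note shows. Statements on the series, on what has been measured and on what is new or still open speak of the compounds shown alone.

In an ADME assay on microsomes from liver (Homo sapiens) for metabolic stability, read by HPLC, with a stated time of 30 min, tested at 0.5 uM (on this read-out lower numbers stand for slow clearance and higher numbers for fast clearance), compound 1 (`CCC/N=C1\S/C(=C\c2ccc(O)cn2)C(=O)N1c1ccccc1C`) gives 2.8 mL.min-1.g-1 and stands level with compound 2 (`CCC/N=C1\S/C(=C\c2ccc(O)cc2)C(=O)N1c1ccccc1C`), which gives 2.4 mL.min-1.g-1 on the same read-out. These two values lie within the scatter of each other. Compound 3 (`CCC/N=C1\S/C(=C\c2ccc(O)c(Cl)c2)C(=O)N1c1ccccc1C`) has not yet been measured. It differs from compound 1 on a double-bonded chain carbon bound to a double-bonded ring carbon (3-chloro-4-hydroxyphenyl in place of 5-hydroxypyridin-2-yl on a double-bonded chain carbon bound to a double-bonded ring carbon), with 3-chloro-4-hydroxyphenyl in place of 5-hydroxypyridin-2-yl. Among the measured compounds shown here, only one measured step bears on this change, the exchange of 5-hydroxypyridin-2-yl for 4-hydroxyphenyl, which amounts to a 1.2-fold lower number from compound 1 to compound 2 (0.07 log units; within the scatter) and gives a small step as the only guide. For the measured compounds named here, no measured compound carries the chlorine of 3-chloro-4-hydroxyphenyl, so what it adds remains open and the range has to stay wide. The expected move in this assay is therefore a 1.1-fold higher number from compound 1 to compound 3 (0.06 log units; within the scatter) and this estimate stays within the scatter. Compound 3 is expected at 3.2 mL.min-1.g-1 (estimated range 1.5 mL.min-1.g-1 to 6.5 mL.min-1.g-1).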

Compound 3, intrinsic clearance in microsomes: 1.6 mL.min-1.g-1
For compound 3 the middle estimate is 2.0-fold (0.30 log units) above the measured one; measured number inside the range.
By their numbers in this assay, from the lowest: compounds 3, 2 and 1 (each within the scatter of the next).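

In this assay, 3-chloro-4-hydroxyphenyl in place of 5-hydroxypyridin-2-yl on a double-bonded chain carbon bound to a double-bonded ring carbon amounts to a 1.8-fold lower number from compound 1 to compound 3 (0.24 log units; within the scatter) and chloro in place of hydrogen on an aromatic carbon, read alone, amounts to a 1.5-fold lower number from compound 2 to compound 3 (0.18 log units; within the scatter) with neither step leaving the scatter. The earlier pair had shown only that a ring nitrogen could be exchanged for carbon at this place without a step beyond the scatter; compound 3 now shows the same for a chlorine-bearing ring, so all three aromatic groups shown here read alike on this measure. Nothing given here accounts for how close these values lie.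

The compounds shown leave open whether any substituent on this aromatic ring can move the number beyond the scatter, as a fluorine, a methoxy group, an amine or a carboxylic acid might or might not. They also leave open what happens when the hydroxy group itself gives way to a methoxy group or to hydrogen on the same ring, with or without the chlorine.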